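This account rests on a few compounds, and the source may have more. Where it says the series, first, only, none or still open, it means among the compounds named here.

Of the compounds shown here, two have been measured in a functional assay on ECa-109 cells (Homo sapiens) for antiproliferative activity, with a stated time of 72 h; on this read-out lower numbers stand for stronger inhibition and higher numbers for weaker inhibition. Compound 1, `COc1cc(OC)c2c(=O)cc(-c3ccccc3Cl)oc2c1CN1CCCCC1`, and compound 2, `COc1cc(OC)c(C(=O)/C=C/c2ccccc2Cl)c(O)c1CN(C)CCCN(C)C`, share the same pair of methoxy groups and the same chlorophenyl group, but their cores differ, and so does the amine attached to the saturated chain carbon bound to an aromatic carbon. In this assay compound 1 gives 23700 nM. In this assay compound 2 gives 3800 nM, the lowest of the two numbers, and its gap to compound 1 lies beyond the usual scatter of repeated measurements.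

Compound 3, `COc1cc(OC)c(C(=O)/C=C/c2ccccc2Cl)c(O)c1CN1CCCC1`, keeps the core of compound 2 and changes only the amine: pyrrolidin-1-yl in place of (3-(dimethylamino)propyl)(methyl)amino on a saturated chain carbon bound to an aromatic carbon. Within the data shown here, no pair of measured compounds differing in just one place is available, so the size of this step cannot be read off from data; the comparison with compound 1 involves a different core and does not settle it. A modest rise in the number, close to the edge of the scatter, is expected, and the step of a 1.7-fold higher number from compound 2 to compound 3 (0.23 log units; within the scatter) is the estimate. Compound 3 is therefore expected to give about 6500 nM, with a range from 2000 nM to 20000 nM.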

Compound 3, half-maximal inhibitory concentration: 6900 nM
Estimate against measurement, compound 3: 1.1-fold (0.03 log units) below; the measured number falls inside the stated range.
By their numbers in this assay, from the lowest: compounds 2 and 3 (each within the scatter of the next); then compound 1.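

In this assay, among these compounds, the core stays fixed for the first time and the step reads a 1.8-fold higher number from compound 2 to compound 3 (0.26 log units; within the scatter) when only the amine on the saturated chain carbon bound to an aromatic carbon changes. The open (3-(dimethylamino)propyl)(methyl)amino chain, with its second nitrogen, can thus give way to pyrrolidin-1-yl, which has one five-membered non-aromatic ring, without the number leaving the usual scatter of repeated measurements. The gap between compound 1 and compound 2 mixes a change of core with a change of amine, whereas this pair isolates the amine alone and shows that, for these two amines, the choice makes no clear difference. Nothing shown here explains why these two amines read alike.

Among the compounds shown here, what the core alone contributes stays open, as no two compounds here carry the same amine on different cores. Also open, on these data alone, is how a morpholine ring or a plain dimethylamino group on the same saturated chain carbon would read in this assay, and whether any amine at this place would move the number beyond the scatter.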